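Swapping the halogen on the aryl ketone of compound 2

A few compounds are considered here, and "the series" means these few. Any claim that something is new, unique, unknown or untested is made for them only; others in the source may bear on it.

Compound 1 `COc1cc(-c2nnc(SCC(=O)c3ccc(Br)cc3)n2N)cc(OC)c1OC` and compound 2 `COc1cc(-c2nnc(SCC(=O)c3cccc(Br)c3)n2N)cc(OC)c1OC` share a core and differ only in the bromophenyl attached to the carbonyl carbon. In a functional assay on PC-3 cells (Homo sapiens) for antiproliferative activity, read by MTT assay, with a stated time of 48 h (a lower number here means a stronger inhibitor, a higher number a weaker inhibitor), compound 1 gives > 100000 nM, which is a limit of the assay. In this assay compound 2 gives > 100000 nM, likewise a limit. The step that the two limits leave unreadable from compound 1 to compound 2 therefore has no readable size, as the limit of > 100000 nM in this assay, at which 2 of the 2 values shown sit, shows both values resting at the same limit. Compound 2 thus stands at the limit of this assay, with no number beneath it.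

Compound 3 `COc1cc(-c2nnc(SCC(=O)c3ccccc3F)n2N)cc(OC)c1OC` is the next member and has not yet been measured in this assay. It differs from compound 2 by 2-fluorophenyl in place of 3-bromophenyl on a carbonyl carbon. Going by the values given here, the only measured step, a step that the two limits leave unreadable from compound 1 to compound 2, also exchanged one halophenyl for another on the carbonyl carbon and gave nothing readable, so no direction can be drawn from it. The step of a number no higher from compound 2 to compound 3 (the limit leaves the size open) is accordingly expected to be none beyond the scatter. Compound 3 is estimated to give 100000 nM in this assay, within 30000 nM to 300000 nM, most likely reported again only as a limit.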

Compound 3, half-maximal inhibitory concentration: 43100 nM
Beside the measured number, compound 3's estimate is 2.3-fold (0.37 log units) above it, within the range that was stated.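

The aryl group on the carbonyl carbon turned out to be able to shift the read-out in this assay, something the two bromophenyl compounds alone could not show, and compound 3 is the only one of the three that gives a number rather than a limit. Replacing 3-bromophenyl with 2-fluorophenyl at this place gives an at least 2.3-fold lower number from compound 2 to compound 3 (0.36 log units; beyond the scatter), and replacing 4-bromophenyl with it gives an at least 2.3-fold lower number from compound 1 to compound 3 (0.36 log units; beyond the scatter). Both steps remain open at their upper end, and neither of the two bromophenyl compounds can be ranked against the other, since their values rest at the same limit: the limit of > 100000 nM in this assay, at which 2 of the 3 values shown sit.

As far as these compounds go, the change to compound 3 alters the halogen and its place on the ring together, and what a 2-bromophenyl or a 3-fluorophenyl group would give on the same carbonyl carbon remains open, leaving the contributions of the two unseparated. Also open, from the compounds shown here alone, is whether an unsubstituted phenyl, a 2-chlorophenyl or a 2-aminophenyl group at this place would give a lower number in this assay than compound 3 does.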